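Swapping 4-chlorophenyl for 3,4-dihydroxyphenyl on a shared core

The source may report more compounds than this note shows. Statements on the series, on what has been measured and on what is new or still open speak of the compounds shown alone.

Compound 1 `O=C1/C(=C\c2ccccc2)S/C(=N/c2ccccc2)N1Cc1ccncc1` gives 26400 nM
Compound 2 `O=C1/C(=C\c2ccc(Cl)cc2)S/C(=N/c2ccccc2)N1Cc1ccncc1` gives 54900 nM

In a functional assay on MCF7 cells (Homo sapiens) for cytotoxicity, read by MTT assay, with a stated time of 48 h (a higher number here means a weaker inhibitor, a lower number a stronger inhibitor), compound 2 holds the higher of the two numbers (54900 nM). Going by the values given here, the only measured step, chloro in place of hydrogen on an aromatic carbon, is modest (a 2.1-fold higher number from compound 1 to compound 2 (0.32 log units; beyond the scatter)). Compound 3 `O=C1/C(=C\c2ccc(O)c(O)c2)S/C(=N/c2ccccc2)N1Cc1ccncc1` replaces 4-chlorophenyl with 3,4-dihydroxyphenyl (3,4-dihydroxyphenyl in place of 4-chlorophenyl on a double-bonded chain carbon bound to a double-bonded ring carbon). Among the compounds with values here, no measured compound carries this group, so the evidence is thin. Compound 1, which lacks the chloro, gives the lower number (26400 nM), which suggests a modest drop. The expected change is a 2.7-fold lower number from compound 2 to compound 3 (0.44 log units; beyond the scatter) in this assay. Compound 3 is estimated at 20000 nM (expected range 6000 nM to 60000 nM).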

Compound 3, half-maximal inhibitory concentration: 12400 nM
The estimate for compound 3 lay 1.6-fold (0.21 log units) above the measured number, and the stated range covers the measured number.
By their numbers in this assay, from the lowest: compound 3; then compound 1; then compound 2.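

In this assay, changing the group on this double-bonded chain carbon can move the number down as well as up: 3,4-dihydroxyphenyl gives a 4.4-fold lower number from compound 2 to compound 3 (0.65 log units; beyond the scatter) and also a 2.1-fold lower number from compound 1 to compound 3 (0.33 log units; beyond the scatter). The second step matters most, since it shows that compound 3 improves on the plain phenyl of compound 1, and not only on the chloro compound. Nothing measured here explains this change.

On these data alone, whether a single hydroxy group would give the same drop remains open. So does the effect of an amine or a carboxylic acid on this phenyl ring.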